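Taking the ring hydroxy off compound 2

The compounds below may be only part of what the source reports. "The series", "measured", "known", "first", "only" and "open" are said of these compounds alone.

Measured so far in a functional assay on MDA-MB-231 cells (Homo sapiens) for cytotoxicity, read by MTT assay, with a stated time of 24 h; on this read-out higher numbers stand for weaker inhibition and lower numbers for stronger inhibition:
Compound 1 `C[C@H]1O[C@]1(C)C(=O)C[C@H]1[C@](C)(O)CC[C@@]2(O)C(C)(C)CCC[C@]12C`: > 10000 nM
Compound 2 `C/C=C(\C)C(=O)C[C@@H]1[C@@]2(C)[C@@H](O)CCC(C)(C)[C@]2(O)CC[C@@]1(C)O`: > 10000 nM

In this assay compound 2 gives > 10000 nM, which is a limit and not a number. Compound 1 gives > 10000 nM, which is also a limit. Among the measured compounds shown here, the series so far therefore offers only (the limit of > 10000 nM in this assay, at which 2 of the 2 values shown sit). For the measured compounds named here, compound 2 has no number from which a step could be counted, and no pair of measured compounds shows a step of any size.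

Compound 3 `C/C=C(\C)C(=O)C[C@H]1[C@](C)(O)CC[C@@]2(O)C(C)(C)CCC[C@]12C` is compound 2 with one change: hydrogen in place of hydroxy on a saturated ring carbon. In short, hydrogen stands in place of hydroxy on a saturated ring carbon, and the rest of the structure is unchanged.

No step beyond the scatter is expected in this assay, in either direction. This expectation rests on compound 2, with its limit of > 10000 nM. The expected change is a step that the limit leaves unreadable from compound 2 to compound 3. A reported limit is the likeliest outcome, and any number that does appear is expected to lie close to that limit. For compound 3 the estimated half-maximal inhibitory concentration is 15000 nM, with an expected range of 7000 nM to 40000 nM.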

Compound 3, half-maximal inhibitory concentration: > 10000 nM
Compound 3: no number, only a limit; the forecaster's own chance of this, stated with the estimate: 85%; the middle value is on the limit's open side.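

In this assay compound 3 gives > 10000 nM, which is a limit and not a number. No step from compound 2 or compound 1 to compound 3 can be read, and the series offers only: the limit of > 10000 nM in this assay, at which 3 of the 3 values shown sit.

Left open is whether hydrogen in place of hydroxy on a saturated ring carbon changes the half-maximal inhibitory concentration at all.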